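A few compounds are considered here, and "the series" means these few. Any claim that something is new, unique, unknown or untested is made for them only; others in the source may bear on it.

Measured so far in an ADME assay on microsomes from liver (Rattus norvegicus) for metabolic stability; a lower number here means that the compound disappears faster, a higher number that the compound lasts longer:
- Compound 1 `N#Cc1ccc(NCCNc2ncc(-c3ncc[nH]3)c(-c3ccc(Cl)cc3Cl)n2)nc1`: > 0.5 h (a limit)
- Compound 2 `FC(F)(F)c1ccc(NCCNc2ncc(-c3ncc[nH]3)c(-c3ccc(Cl)cc3Cl)n2)nc1`: > 0.5 h (a limit)

Compound 2 stands at > 0.5 h, which is a limit of this assay and not a number. Compound 1 gives > 0.5 h, which is also only a limit. Going by the values given here, the one measured step is a step that the two limits leave unreadable from compound 1 to compound 2, with trifluoromethyl in place of cyano on an aromatic carbon. All that the data show so far is the limit of > 0.5 h in this assay, at which 2 of the 2 values shown sit.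

The next compound is compound 3 `Clc1ccc(-c2nc(NCCNc3ccccn3)ncc2-c2ncc[nH]2)c(Cl)c1`, and the change from compound 2 is hydrogen in place of trifluoromethyl on an aromatic carbon. This puts hydrogen in place of trifluoromethyl on an aromatic carbon, para to a large group. Among the compounds with values here, neither measured compound carries hydrogen at this place, and the one measured step has no readable size to carry over. No change beyond the usual scatter is therefore expected, and no direction can be given.

The expected outcome is a number no higher from compound 2 to compound 3 (the limit leaves the size open), and this remains a loose estimate. For compound 3 the estimated half-life is 0.5 h, with an expected range from 0.25 h to 1 h.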

Compound 3, half-life: > 0.5 h
Compound 3: no number, only a limit; the forecaster's own chance of this, stated with the estimate: 60%; the middle value lies on the limit itself.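

The steps among compound 1, compound 2 and compound 3 cannot be read, since none of the three has a number, only a limit of the assay: the limit of > 0.5 h in this assay, at which 3 of the 3 values shown sit.

How long each of these compounds actually lasts in this assay, and whether cyano, trifluoromethyl or hydrogen at this place makes any difference to that, stays open.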